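Hydroxy in Place of Hydrogen: From Compound 2 to Compound 3

The source may report more compounds than this note shows. Statements on the series, on what has been measured and on what is new or still open speak of the compounds shown alone.

compound 1 `N=C(NCc1ccc(O)cc1)[C@@H]1CCC(=O)N1Cc1ccccc1[N+](=O)[O-]`: 26.9%
compound 2 `N=C(NCc1ccccc1)[C@@H]1CCC(=O)N1Cc1ccc(F)cc1`: 23.3%

In a functional assay on SH-SY5Y cells (Homo sapiens) for cytotoxicity, read by MTT assay, with stated times of 8 h, 30 min and 12 h, tested at 0.5 uM (a higher number here means a stronger effect of the compound at the concentration tested, a lower number a weaker effect), compound 1 gives 26.9%. In this assay compound 2 gives 23.3%. The two numbers lie within the usual scatter of each other, so compound 2 does not stand apart from compound 1. Compound 3 `N=C(NCc1ccc(O)cc1)[C@@H]1CCC(=O)N1Cc1ccc(F)cc1` differs from compound 2 in one place: hydroxy in place of hydrogen on an aromatic carbon. Within the data shown here, no measured pair shows what this change does on its own. For compound 3 the expected step is a number 1.7 percentage points higher from compound 2 to compound 3 (within the scatter), none beyond the scatter. The estimate for compound 3 is 25%, with a range from 12% to 38%.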

Compound 3, a percentage reported as activity, at one concentration (the size of the read-out at that concentration, not a potency): 42%
Beside the measured number, compound 3's estimate is 17 percentage points below it, and the stated range ends below it.
By their numbers in this assay, from the lowest: compounds 2 and 1 (each within the scatter of the next); then compound 3.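

On the 4-hydroxybenzyl side, a single hydroxy on the aromatic ring changes the outcome in this assay, giving a number 18.7 percentage points higher from compound 2 to compound 3 (beyond the scatter), so this position responds to the change. With that 4-hydroxybenzyl group kept, 4-fluorophenyl in place of 2-nitrophenyl gives a number 15.1 percentage points higher from compound 1 to compound 3 (beyond the scatter), so the group at the other end of the molecule also affects the number. Nothing shown here explains either rise. Still open, from the compounds shown here alone, is whether a methoxy group or an amine at the same place would raise the number as well.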